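The source may report more compounds than this note shows. Statements on the series, on what has been measured and on what is new or still open speak of the compounds shown alone.

Measured so far:
- Compound 1 `Fc1ccc(CN2CCC(NCCSC(c3ccc(F)cc3)c3ccc(F)cc3)CC2)cc1`: 25.5 nM
- Compound 2 `Fc1ccc(C(SCCNC2CCN(Cc3cc4ccccc4[nH]3)CC2)c2ccc(F)cc2)cc1`: 179 nM

Both numbers come from an assay on membranes from striatum (strain Sprague-Dawley) for displacement of a labelled ligand from sodium-dependent dopamine transporter (Rattus norvegicus), read by scintillation counting, with a stated time of 120 min; a higher number here means a weaker inhibitor, a lower number a stronger inhibitor. Compound 2 stands higher of the two values, as a 7.0-fold higher number from compound 1 to compound 2 (0.85 log units; beyond the scatter) shows. Compound 3 `O=C(c1ccccc1F)N1CCC(NCCSC(c2ccc(F)cc2)c2ccc(F)cc2)CC1` has not been measured; it differs from compound 2 by (2-fluorophenyl)carbonyl in place of (1H-indol-2-yl)methyl on an amine nitrogen in a ring. Going by the values given here, only one measured step touches this position, a 7.0-fold higher number from compound 1 to compound 2 (0.85 log units; beyond the scatter), where the 4-fluorophenyl group gave the lower number. Among the compounds with values here, compound 3 brings a fluorine-bearing phenyl group back to that place, but joined through a carbonyl rather than a saturated carbon, and no measured pair shows what the carbonyl itself does. The step from compound 2 to compound 3 is therefore expected to move the number partway back toward compound 1, by about a 3.0-fold lower number from compound 2 to compound 3 (0.47 log units; beyond the scatter). For compound 3 the estimated value is 60 nM, with a likely range from 15 nM to 250 nM.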

Compound 3, inhibition constant: 46.1 nM
Compound 3: the middle estimate sits 1.3-fold (0.11 log units) above what was measured, and the stated range covers the measured number.
By their numbers in this assay, from the lowest: compounds 1 and 3 (each within the scatter of the next); then compound 2.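

Replacing (1H-indol-2-yl)methyl with (2-fluorophenyl)carbonyl on the ring nitrogen gives a 3.9-fold lower number from compound 2 to compound 3 (0.59 log units; beyond the scatter) and so shows that the higher number of compound 2 is not a fixed feature of this position. Set against 4-fluorobenzyl, the same group gives a 1.8-fold higher number from compound 1 to compound 3 (0.26 log units; within the scatter) and so cannot be told apart from it, which shows that a carbonyl link at this nitrogen can fit as well as a saturated carbon link, at least with a fluorinated phenyl ring attached. Nothing given here explains either result.

The step between compound 1 and compound 3 changes both the link and the place of the fluorine, so the effect of each stays unresolved. A 2-fluorobenzyl group or a 4-fluorobenzoyl group would separate the two, and an unsubstituted benzoyl group would show whether the fluorine matters at all.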